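Swapping Methoxy for Methylpiperazine on Two Related Cores

The source may report more compounds than this note shows. Statements on the series, on what has been measured and on what is new or still open speak of the compounds shown alone.

Compound 1 `COc1ccc(-c2cc3[nH]nc(N)c3c(=O)[nH]2)cc1` and compound 2 `CN1CCN(c2ccc(-c3cc4[nH]nc(N)c4c(=O)[nH]3)cc2)CC1` share a core and differ in one place: 4-methylpiperazin-1-yl in place of methoxy on an aromatic carbon. In an assay on isolated protein for inhibition of RAC-alpha serine/threonine-protein kinase (Homo sapiens), read by mobility shift assay, tested at 30 uM (on this read-out lower numbers stand for less inhibition and higher numbers for more inhibition at the one concentration tested (going by the name of the read-out)), compound 1 gives 21%, while compound 2 gives 9%, which is a step of a number 12 percentage points lower from compound 1 to compound 2 (beyond the scatter). Compound 3 `COc1ccc(-c2cc3nn(-c4ccccc4)c(N)c3c(=O)[nH]2)cc1` is built on a different core; the difference between the two cores is not broken down here. In this assay compound 3 gives 16%, which lies within the scatter of both compound 1 and compound 2. Compound 4 `CN1CCN(c2ccc(-c3cc4nn(-c5ccccc5)c(N)c4c(=O)[nH]3)cc2)CC1` arises from compound 3 by the same change: 4-methylpiperazin-1-yl in place of methoxy on an aromatic carbon. Because the same change once gave a number 12 percentage points lower from compound 1 to compound 2 (beyond the scatter), a step of about a number 12 percentage points lower from compound 3 to compound 4 (beyond the scatter) is expected in this assay. Compound 4 is therefore estimated at 4%, with a likely range from -6% to 15%. Whether the second core carries this change in the same way remains to be seen.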

Compound 4, a percentage reported as inhibition, at one concentration (the size of the read-out at that concentration, not a potency): 3%
Estimate against measurement, compound 4: 1 percentage points above; the measured number falls inside the stated range.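

In this assay, putting 4-methylpiperazin-1-yl in place of methoxy goes with a number 13 percentage points lower from compound 3 to compound 4 (beyond the scatter), and this step matches the earlier one on the other core: the same change on two cores in this assay, a number 12 percentage points lower (beyond the scatter) from compound 1 to compound 2 and a number 13 percentage points lower (beyond the scatter) from compound 3 to compound 4, 1 percentage points apart, within the scatter of two such steps. On these two cores, then, the change carried over at about the same size, so the step measured on one core was a fair guide to the step on the other. This does not show that the change would carry over to any further core, and each number is a reading at one concentration, not a potency.

The compounds shown leave open how other groups in this place would behave, such as a morpholine ring, a simple amine or a carboxylic acid.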